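Piperazinyl in place of benzylamino on the bromo core

This account rests on a few compounds, and the source may have more. Where it says the series, first, only, none or still open, it means among the compounds named here.

Measured so far:
- compound 1 `N[C@H]1CC[C@H](Nc2c(C(=O)NCc3ccc(F)cc3)nc(N3CCCCC3)c3cccnc23)CC1`: 8500 nM in a functional assay on HCT-116 cells (Homo sapiens) for cytotoxicity, read by MTT assay, with a stated time of 72 h; a higher number here means a weaker inhibitor, a lower number a stronger inhibitor
- compound 2 `O=C(NCc1ccc(F)cc1)c1nc(Br)c2cccnc2c1NCc1ccccc1`: only a limit in this assay, > 20000 nM
- compound 3 `CS(=O)(=O)NCCCCCCN(c1nc(C(=O)NCc2ccc(F)cc2)c(O)c2ncccc12)S(C)(=O)=O`: 4000 nM in this assay

Compound 2 stands at the edge of what this assay can report: its value is a limit, not a number, and it is the one of the three that sits at the limit of > 20000 nM in this assay, at which 1 of the 3 values shown sits. Compound 1 and compound 3 both return numbers, and both of these carry an amine-bearing side chain where compound 2 carries benzylamino.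

The next compound, compound 4 `O=C(NCc1ccc(F)cc1)c1nc(Br)c2cccnc2c1N1CCNCC1`, keeps the bromo core of compound 2 and changes one group: piperazin-1-yl in place of benzylamino on an aromatic carbon.

Going by the values given here, no measured step bears on this change. The expectation is that compound 4 comes back into the measurable range, but not far into it: the step of an at least 1.6-fold lower number from compound 2 to compound 4 (0.22 log units; that floor lies within the scatter) is expected to lie at or just beyond the scatter, in the direction of stronger inhibition. Compound 4 is estimated at 12000 nM, with a range of 4000 nM to 40000 nM.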

Compound 4, half-maximal inhibitory concentration: > 10000 nM
Compound 4 ended at the assay's limit; the forecaster's own chance of this, stated with the estimate: 40%; the middle value is on the limit's open side.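

In this assay compound 4 gives only a limit, > 10000 nM. Compound 2 also gives only a limit, > 20000 nM. The step between compound 2 and compound 4 cannot be read. The compounds shown leave open whether piperazin-1-yl in place of benzylamino on an aromatic carbon shifts the value in this assay at all.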